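Swapping a halogen for methoxy on a shared core

The source may report more compounds than this note shows. Statements on the series, on what has been measured and on what is new or still open speak of the compounds shown alone.

Measured compounds:
compound 1 `O=c1c2ccccc2[se]n1-c1nnc(-c2ccc(Br)cc2)s1` gives 68200 nM
compound 2 `O=c1c2ccccc2[se]n1-c1nnc(-c2ccc(Cl)cc2)s1` gives 24400 nM

In a functional assay on SSMC-7721 cells (Homo sapiens) for antiproliferative activity, read by CCK-8 assay, with a stated time of 48 h (on this read-out higher numbers stand for weaker inhibition and lower numbers for stronger inhibition), compound 2 stands lowest of the two numbers; its nearest neighbour is compound 1, and the step of a 2.8-fold lower number from compound 1 to compound 2 (0.45 log units; beyond the scatter) is beyond the scatter. Compound 3 `COc1ccc(-c2nnc(-n3[se]c4ccccc4c3=O)s2)cc1` differs from compound 2 by methoxy in place of chloro on an aromatic carbon. Among the compounds with values here, only one step is known on this core, and it exchanges one halogen for another; no measured pair exchanges a halogen for a methoxy group, so that step offers only a loose guide. With nothing closer to rest on, compound 3 is expected to give a number near that of compound 2, so the estimated step of a 1.2-fold higher number from compound 2 to compound 3 (0.09 log units; within the scatter) stays within the scatter. Compound 3 is therefore estimated at 30000 nM, with a broad range from 8000 nM to 120000 nM.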

Compound 3, half-maximal inhibitory concentration: 16500 nM
For compound 3 the middle estimate is 1.8-fold (0.26 log units) above the measured one, within the range that was stated.
By their numbers in this assay, from the lowest: compounds 3 and 2 (each within the scatter of the next); then compound 1.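

In this assay, methoxy on this aromatic carbon, para to a large group, cannot be told apart from chloro (a 1.5-fold lower number from compound 2 to compound 3 (0.17 log units; within the scatter)), so this place accepts a group that is not a halogen without a step beyond the scatter. Against bromo, the same group gives a step beyond the scatter (a 4.1-fold lower number from compound 1 to compound 3 (0.62 log units; beyond the scatter)), which leaves compound 1 apart from both compound 2 and compound 3. Nothing available here explains why these numbers fall as they do.

The three compounds differ only at this one place, so they do not tell how an amine, a carboxylic acid or a longer chain would fare there. As far as these compounds go, all three numbers also come from one cell assay, so whether this picture holds in other cells remains open.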